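A few compounds are considered here, and "the series" means these few. Any claim that something is new, unique, unknown or untested is made for them only; others in the source may bear on it.

In a functional assay on EBC-1 cells (Homo sapiens) for inhibition, read by sulforhodamine B assay, with a stated time of 72 h (a higher number here means a weaker inhibitor, a lower number a stronger inhibitor), compound 1 (`COc1ccc2c(OCCn3c(=O)oc4cc(C)ccc43)ccnc2c1`) gives > 500 nM, which is a limit of the assay. Compound 2 (`Cc1ccc2c(c1)oc(=O)n2CCOc1ccnc2cc(OCCCN3CCN(C)CC3)ccc12`), which carries a 2-(4-methylpiperazin-1-yl)ethyl group on the chain at the oxygen, gives 170 nM. Compound 3 (`COC(=O)c1ccc2c(c1)oc(=O)n2CCOc1ccnc2cc(OC)ccc12`) gives > 500 nM, again a limit. Compound 3 therefore has no number of its own and stands at the limit of > 500 nM in this assay, at which 2 of the 3 values shown sit.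

The next compound, compound 4 (`COc1ccc2c(OCCn3c(=O)oc4cc(N)ccc43)ccnc2c1`), has amino in place of methoxycarbonyl on an aromatic carbon. Among the measured compounds shown here, two measured steps bear on this change, and neither gives a size to carry over. The only one at this aromatic carbon is a step that the two limits leave unreadable from compound 1 to compound 3, with methoxycarbonyl in place of methyl. The only readable one is an at least 2.9-fold lower number from compound 1 to compound 2 (0.46 log units; beyond the scatter), but it was made elsewhere on the molecule, and compound 4 does not carry the 2-(4-methylpiperazin-1-yl)ethyl group of compound 2. For the measured compounds named here, no step of a particular size or direction can therefore be expected in this assay, and compound 4 is expected to stay close to the limit, quite possibly without a number of its own. The expected step is a step that the limit leaves unreadable from compound 3 to compound 4. For compound 4 the estimated value is 700 nM, within an expected range from 250 nM to 2000 nM.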

Compound 4, half-maximal inhibitory concentration: 160 nM
Beside the measured number, compound 4's estimate is 4.4-fold (0.64 log units) above it; measured number below the stated range.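

At this aromatic carbon, part of a six-membered aromatic ring of carbon only, the compounds now give a readable step in this assay: amino in place of methoxycarbonyl gives an at least 3.1-fold lower number from compound 3 to compound 4 (0.49 log units; beyond the scatter), and amino in place of methyl gives an at least 3.1-fold lower number from compound 1 to compound 4 (0.49 log units; beyond the scatter). The earlier compounds shown here showed a readable step only from the change on the chain at the oxygen, whereas compound 4 shows that a single change at this carbon also moves the number beyond the scatter, without the 2-(4-methylpiperazin-1-yl)ethyl group of compound 2. Both new steps give only a least size, and the steps that start from or end at two limits still cannot be read: the limit of > 500 nM in this assay, at which 2 of the 4 values shown sit.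

Amino is the only group at this carbon with a number of its own, so it remains open whether a hydroxyl, a methylamino or an acetamide group there would behave in the same way as amino, which enters with a hydrogen-bond donor that methoxycarbonyl lacks. On these data alone, it is also open what amino at this carbon would do in a molecule that also carries the 2-(4-methylpiperazin-1-yl)ethyl group of compound 2.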